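Fluoro to methyl on the sulfonyl aryl group

The source may report more compounds than this note shows. Statements on the series, on what has been measured and on what is new or still open speak of the compounds shown alone.

Measured so far:
Compound 1 `COc1ncc(-c2ccc3nc(NC(=O)NCCN4CCCC4)sc3c2)cc1NS(=O)(=O)c1ccc(F)cc1` gives 360 nM in a functional assay on U-87MG ATCC cells for antiproliferative activity against U-87 MG (Homo sapiens), read by MTT assay, with a stated time of 72 h; on this read-out higher numbers stand for weaker inhibition and lower numbers for stronger inhibition.
Compound 2 `CCN(CC)CCNC(=O)Nc1nc2ccc(-c3cnc(OC)c(NS(=O)(=O)c4ccc(F)cc4)c3)cc2s1` gives 390 nM in this assay.
Compound 3 `COc1ncc(-c2ccc3nc(NC4CC4)sc3c2)cc1NS(=O)(=O)c1ccc(F)cc1` gives 1500 nM in this assay.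

Compound 2 holds the second highest of the three numbers. Its nearest neighbour is compound 1, a 1.1-fold higher number from compound 1 to compound 2 (0.03 log units; within the scatter), so the two cannot be told apart on these data. Its furthest is compound 3, a 3.8-fold higher number from compound 2 to compound 3 (0.59 log units; beyond the scatter). The remaining step, a 4.2-fold higher number from compound 1 to compound 3 (0.62 log units; beyond the scatter), is the same kind of change: cyclopropyl in place of the carbamoyl side chain on a nitrogen on an aromatic ring of the shared core.

Compound 4 `CCN(CC)CCNC(=O)Nc1nc2ccc(-c3cnc(OC)c(NS(=O)(=O)c4ccc(C)cc4)c3)cc2s1` differs from compound 2 in one place only: methyl in place of fluoro on an aromatic carbon. For the measured compounds named here, no measured step bears on this part of the molecule. All three measured compounds carry the (4-fluorophenyl)sulfonyl group unchanged, and the two steps that are beyond the scatter both concern the side chain on the core nitrogen, not the sulfonyl-bearing ring. Going by the values given here, with no precedent for this exchange, the default expectation is a step within the scatter in this assay, in no particular direction; the estimated step is a 1.0-fold higher number from compound 2 to compound 4 (0.01 log units; within the scatter). Compound 4 is therefore expected to give about 400 nM in this assay, within a range of 200 nM to 900 nM.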

Compound 4, half-maximal inhibitory concentration: 360 nM
The estimate for compound 4 lay 1.1-fold (0.05 log units) above the measured number; the range from low to high includes it.
By their numbers in this assay, from the lowest: compounds 1, 4 and 2 (each within the scatter of the next); then compound 3.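

In this assay the exchange of fluoro for methyl on the aromatic carbon para to a large group gives a 1.1-fold lower number from compound 2 to compound 4 (0.03 log units; within the scatter) and so leaves the read-out unresolved from that of compound 2. For the compounds shown here, this is the first measured change on the sulfonyl-bearing ring, and it extends what the earlier steps showed, which concerned only the side chain on the core nitrogen: within this pair, (4-fluorophenyl)sulfonyl and (4-methylphenyl)sulfonyl cannot be told apart, and fluoro is not needed at this position to hold the number in this range. No supporting measurement is available to account for the two groups reading alike.

Still open, on these data alone, is how far this position tolerates groups other than these two, such as trifluoromethyl, methoxy, a carboxylic acid or an aminomethyl group on the same carbon, any of which might move the number beyond the scatter. Also open, as far as these compounds go, is whether the same exchange stays this quiet on the pyrrolidin-1-yl side chain of compound 1 or on the cyclopropyl-bearing nitrogen of compound 3.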